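This account rests on a few compounds, and the source may have more. Where it says the series, first, only, none or still open, it means among the compounds named here.

Measured so far:
- compound 1, `COc1ccc(S(=O)(=O)N2CCc3cccc(-c4ccc([N+](=O)[O-])cc4)c32)cc1`, in a functional assay on KB cells (Homo sapiens) for inhibition, with a stated time of 72 h (on this read-out higher numbers stand for weaker inhibition and lower numbers for stronger inhibition), gives 52.5 nM
- compound 2, `COc1ccc(S(=O)(=O)N2CCc3cccc(-c4ccc(F)nc4)c32)cc1`, gives 143 nM
- compound 3, `COc1ccc(-c2cccc3c2N(S(=O)(=O)c2ccc(OC)cc2)CC3)cc1`, gives 337 nM

Compound 1 thus has the lowest number of the three, with a 2.7-fold higher number from compound 1 to compound 2 (0.44 log units; beyond the scatter) and a 6.4-fold higher number from compound 1 to compound 3 (0.81 log units; beyond the scatter) both beyond the scatter. Compound 4, `COc1ccc(S(=O)(=O)N2CCc3cccc(-c4ccccc4)c32)cc1`, differs from compound 1 by hydrogen in place of nitro on an aromatic carbon. For the measured compounds named here, the step that bears most directly on this is the one from compound 1 to compound 3, where the nitro group was exchanged for methoxy at the same place and the number rose by a 6.4-fold higher number from compound 1 to compound 3 (0.81 log units; beyond the scatter); the step of a 2.7-fold higher number from compound 1 to compound 2 (0.44 log units; beyond the scatter) also shows that altering this outer ring weakens inhibition. A rise is therefore expected for compound 4, estimated at a 3.0-fold higher number from compound 1 to compound 4 (0.48 log units; beyond the scatter), giving 160 nM with a range from 60 nM to 420 nM.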

Compound 4, half-maximal inhibitory concentration: 120 nM
Compound 4: the middle estimate sits 1.3-fold (0.12 log units) above what was measured, within the range that was stated.
By their numbers in this assay, from the lowest: compound 1; then compounds 4 and 2 (each within the scatter of the next); then compound 3.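

In this assay, a 2.3-fold higher number from compound 1 to compound 4 (0.36 log units; beyond the scatter) shows that the nitro group is not needed for inhibition, though losing it does weaken inhibition. Hydrogen and methoxy also differ at this place, as a 2.8-fold lower number from compound 3 to compound 4 (0.45 log units; beyond the scatter) shows, so relative to hydrogen, one group lowers the number and the other raises it. Changing the outer ring from 6-fluoropyridin-3-yl to phenyl gives a 1.2-fold lower number from compound 2 to compound 4 (0.08 log units; within the scatter) and so makes no clear difference.

No measurement shown explains why these groups differ. Going by these compounds, whether an amine or a carboxylic acid at this place would match the nitro group remains open.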